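Swapping the aryl group on the piperazine of compound 2

A few compounds are considered here, and "the series" means these few. Any claim that something is new, unique, unknown or untested is made for them only; others in the source may bear on it.

Measured so far:
- compound 1, `CCC(C(=O)N1CCN(c2ccccc2)CC1)N1C(=O)CCC1=O`: 25%
- compound 2, `CC(C(=O)N1CCN(c2ccc(Cl)cc2)CC1)N1C(=O)CCC1=O`: 50%
- compound 3, `CCC(C(=O)N1CCN(c2cccc(C(F)(F)F)c2)CC1)N1C(=O)CCC1=O`: 75%

All three compounds were tested in a functional assay on the whole organism (strain Swiss) with Mus musculus as the target, in the maximal electroshock model, with a stated time of 0.25 h, at a dose of 100 mg/kg by the intraperitoneal route; on this read-out higher numbers stand for a stronger effect at the one dose given and lower numbers for a weaker effect. Compound 2 gives 50%, which places it second highest of the three numbers and beyond the scatter from each of the other two, between compound 1 with 25% and compound 3 with 75%.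

The compound not yet measured is compound 4, `Cc1cccc(N2CCN(C(=O)C(C)N3C(=O)CCC3=O)CC2)c1`. It differs from compound 2 in one place: 3-methylphenyl in place of 4-chlorophenyl on an amine nitrogen in a ring.

Within the data shown here, only one step between measured compounds is available, and it is large: a number 50 percentage points higher from compound 1 to compound 3 (beyond the scatter). That step concerns trifluoromethyl in place of hydrogen, not an exchange of one substituted phenyl for another, so it bears only loosely on the present change. Among the measured compounds shown here, there is no measured pair that exchanges a chlorine for a methyl on the aryl ring, so no direct guide exists.

On this basis compound 4 is expected to stay close to compound 2, with a step of no change at the digits printed from compound 2 to compound 4 (within the scatter) in this assay, not clearly beyond the scatter in either direction. The estimate for compound 4 is 50%, with a range from 25% to 75%.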

Compound 4, a percentage reported as activity, at one dose (the size of the read-out at that dose, not a potency): 0%
For compound 4 the middle estimate is 50 percentage points above the measured one, outside the stated range (below it).
By their numbers in this assay, from the lowest: compound 4; then compound 1; then compound 2; then compound 3.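

Exchanging 4-chlorophenyl for 3-methylphenyl on an amine nitrogen in a ring gives, in this assay, a number 50 percentage points lower from compound 2 to compound 4 (beyond the scatter), so the read-out at this place on the shared core depends strongly on which substituted phenyl it carries, even though the two groups have the same count of heavy atoms and neither has a hydrogen-bond donor or acceptor. Compound 4 gives 0%, which shows that this single exchange can leave no measurable effect at the one dose given, whereas the earlier step only showed a gain on adding a group to the phenyl ring. Nothing measured for these compounds explains the size of this step.

This exchange alters both the substituent and its printed position on the phenyl ring, so the compounds shown cannot separate the effect of replacing chlorine with methyl from the effect of moving the substituent. They also leave open how other groups on the phenyl ring, such as a methoxy group or an amine, would behave at this place in the same test.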